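Working notes: methyl in place of hydrogen on compound 3

A few compounds are considered here, and "the series" means these few. Any claim that something is new, unique, unknown or untested is made for them only; others in the source may bear on it.

Values in a functional assay on F9 cells (Mus musculus); a higher number here means that more compound is needed for the effect, a lower number that less compound is needed:
- compound 1 `C/C(=C\c1ccc2c(c1)C(C)(C)CCC2(C)C)c1ccc(C(=O)O)cc1`: 1.5 nM
- compound 2 `C/C(=C(/C)c1ccc2c(c1)C(C)(C)CCC2(C)C)c1ccc(C(=O)O)cc1`: > 100 nM (a limit of the assay)
- compound 3 `CC1(C)CCC(C)(C)c2cc(-c3ccc4cc(C(=O)O)ccc4c3)ccc21`: 31 nM

Among the compounds with values here, only two of the three compounds give true numbers. Compound 3 gives 31 nM, the higher of the two, and compound 1 lies lower at 1.5 nM, a gap beyond the usual scatter. For compound 2 the reading of > 100 nM is a limit and not a number, so it cannot be placed exactly against the others.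

The next compound is compound 4 `Cc1cc2c(cc1-c1ccc3cc(C(=O)O)ccc3c1)C(C)(C)CCC2(C)C`. It differs from compound 3 by methyl in place of hydrogen on an aromatic carbon, ortho to a large group: methyl in place of hydrogen on an aromatic carbon. Within the data shown here, no measured pair in this set isolates such a change, so the expectation rests on the value of compound 3, 31 nM, and on the change itself. The three compounds spread widely in this assay, so the methyl is not assumed to be neutral. The expected step of a 2.6-fold higher number from compound 3 to compound 4 (0.41 log units; beyond the scatter) is a moderate rise in the number, only somewhat beyond the scatter, and the uncertainty on it is wide. For compound 4 the estimated value is 80 nM, with an expected range of 20 nM to 400 nM.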

Compound 4, concentration for half-maximal effect: > 100 nM
Compound 4 ended at the assay's limit (the forecaster's own chance of this, stated with the estimate: 25%); middle value at least 1.2-fold (0.09 log units) away from the limit.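

Within the data shown here, until now no pair isolated a single change, and in this assay methyl in place of hydrogen on an aromatic carbon, ortho to a large group, gives the first readable step: an at least 3.2-fold higher number from compound 3 to compound 4 (0.50 log units; beyond the scatter). Compound 4 gives > 100 nM, which is a limit of the assay and not a number. So this position does not tolerate the added methyl as a neutral change, and the single carbon is enough to take a compound with a true reading to the limit, but the step gives only a lower bound on the size of the change because compound 4 sits at that limit: the limit of > 100 nM in this assay, at which 2 of the 4 values shown sit.

From the compounds shown here alone, how far the number of compound 4 lies past the limit remains open, and so does whether the rise belongs to methyl in particular or to any group at this position. A fluorine, a methoxy or an ethyl on the same aromatic carbon of compound 3 would separate these readings, and would show whether the rise grows with the group.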